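The source may hold more compounds than are shown below. What is called first, only, known or untested is meant among the compounds shown, and "the series" means these compounds.

Compound 2 `CN(C)c1ccc(/C=C2\C(=O)N(c3c(Cl)cccc3Cl)c3ccccc32)cc1` stands at a limit in a functional assay on B16-F10 cells (Homo sapiens) for cytotoxicity against B16-F10 (Mus musculus), read by MTT assay, with a stated time of 72 h (a lower number here means that less compound is needed, a higher number that more compound is needed for the effect), where it gives > 100 ug/mL. Compound 1 `O=C1/C(=C\c2ccc(F)cc2)c2ccccc2N1c1c(Cl)cccc1Cl` gives 38 ug/mL in this assay, and the limit of > 100 ug/mL in this assay, at which 1 of the 2 values shown sits, caps how far the two can be compared. Compound 3 `COc1ccc(/C=C2\C(=O)N(c3c(Cl)cccc3Cl)c3ccccc32)cc1` differs from compound 2 by methoxy in place of dimethylamino on an aromatic carbon. Among the measured compounds shown here, the only measured step, an at least 2.6-fold higher number from compound 1 to compound 2 (0.42 log units; beyond the scatter), shows the dimethylamino group arriving together with a weaker result, so taking it away again is expected to lower the number by an at least 1.6-fold lower number from compound 2 to compound 3 (0.22 log units; that floor lies within the scatter), although compound 3 could again stop at the limit. Compound 3 is therefore expected to give 60 ug/mL, between 25 ug/mL and 150 ug/mL.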

Compound 3, concentration for half-maximal effect: > 100 ug/mL
Compound 3: only a limit was reported; the forecaster's own chance of this, stated with the estimate: 40%; at least 1.6-fold (0.22 log units) between middle value and limit.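

In this assay, methoxy in place of fluoro on an aromatic carbon gives an at least 2.6-fold higher number from compound 1 to compound 3 (0.42 log units; beyond the scatter), so the higher number seen with dimethylamino is now also seen with a second group at this position. Compound 2 and compound 3 both stop at a limit, so the step between them cannot be read: the limit of > 100 ug/mL in this assay, at which 2 of the 3 values shown sit.

The compounds shown leave open how much compound 2 and compound 3 really differ. They also leave open how a plain hydrogen, a chloro group or a carboxylic acid at this position would compare with fluoro.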